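From compound 3 to the vinyl-ended compound 4

A few compounds are considered here, and "the series" means these few. Any claim that something is new, unique, unknown or untested is made for them only; others in the source may bear on it.

In a functional assay on HeLa cells (Homo sapiens) for cytotoxicity, read by MTT assay, with a stated time of 24 h (a lower number here means a stronger inhibitor, a higher number a weaker inhibitor), compound 3 (`CCCCCCCCCCCCCCCC(=O)Nc1nnc(S[C@@H]2O[C@H](CO)[C@H](O)[C@H](O)[C@H]2O)s1`) gives 14200 nM, compound 1 (`CCCCCCCCCC(=O)Nc1nnc(S[C@@H]2O[C@H](CO)[C@H](O)[C@H](O)[C@H]2O)s1`) gives 25900 nM and compound 2 (`CCCCCC(=O)Nc1nnc(S[C@@H]2O[C@H](CO)[C@H](O)[C@H](O)[C@H]2O)s1`) gives 45600 nM. Compound 3 stands beyond the scatter from compound 2 but within it from compound 1. Compound 4 (`C=CCCCCCCCCC(=O)Nc1nnc(S[C@@H]2O[C@H](CO)[C@H](O)[C@H](O)[C@H]2O)s1`) has vinyl in place of heptyl on a saturated chain carbon, eight bonds along the chain from a carbonyl carbon. The nearest guide, read in reverse, is a 1.8-fold lower number from compound 1 to compound 3 (0.26 log units; within the scatter), a chain change of similar reach. The larger 3.2-fold lower number from compound 2 to compound 3 (0.51 log units; beyond the scatter) spans more chain, and a 1.8-fold higher number from compound 1 to compound 2 (0.25 log units; within the scatter) also stays within the scatter. No vinyl-ended chain has been measured. The expected change is a higher number, within the scatter: a 1.7-fold higher number from compound 3 to compound 4 (0.23 log units; within the scatter). Compound 4 is estimated at 24000 nM, with an expected range of 13000 nM to 42000 nM.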

Compound 4, half-maximal inhibitory concentration: 58300 nM
For compound 4 the middle estimate is 2.4-fold (0.39 log units) below the measured one; measured number above the stated range.
By their numbers in this assay, from the lowest: compounds 3, 1, 2 and 4 (each within the scatter of the next, the first and the last beyond it).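

In this assay, vinyl in place of heptyl gives a 4.1-fold higher number from compound 3 to compound 4 (0.61 log units; beyond the scatter) and vinyl in place of methyl gives a 2.3-fold higher number from compound 1 to compound 4 (0.35 log units; beyond the scatter) at the same place, eight bonds along the chain from a carbonyl carbon, so the vinyl-ended chain of compound 4 gives a higher number than either of these saturated chains. Pent-4-en-1-yl in place of hydrogen gives a 1.3-fold higher number from compound 2 to compound 4 (0.11 log units; within the scatter), which leaves compound 4 level with compound 2. Nothing available explains these steps.

Open, from the compounds shown here alone, is whether a longer chain ending in vinyl would match the saturated chain of compound 3. Also open, going by these compounds, is how a chain ending in an alkyne or a carboxylic acid would read.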